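Methyl in place of hydrogen and measured solubility

The source may report more compounds than this note shows. Statements on the series, on what has been measured and on what is new or still open speak of the compounds shown alone.

Compound 1 `CCc1ccc(-c2nc3c(c(C)nn3-c3ccccc3)c(-c3ccccc3O)c2C#N)cc1` is the reference of this set. In a physicochemical assay for solubility, read by spectrophotometry, in phosphate buffer, with a stated time of 18 h, at pH 7.4 (a higher number here means a more soluble compound, a lower number a less soluble compound), compound 1 gives 3100 nM. Compound 2 `CCc1ccc(-c2nc3c(c(C)nn3-c3ccccc3)c(-c3ccccc3C)c2C#N)cc1` gives 6000 nM in this assay, and compound 3 `CCc1ccc(-c2nc3c(c(C)nn3-c3ccccc3)c(-c3ccccc3)c2C#N)cc1` gives 47000 nM. Compound 1 has the lowest of the three numbers; the step of a 1.9-fold higher number from compound 1 to compound 2 (0.29 log units; within the scatter) lies within the scatter, whereas a 15-fold higher number from compound 1 to compound 3 (1.18 log units; beyond the scatter) and a 7.8-fold lower number from compound 3 to compound 2 (0.89 log units; beyond the scatter) lie beyond it.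

Compound 4 `CCc1ccc(-c2nc3c(c(C)nn3-c3ccccc3C)c(-c3ccccc3O)c2C#N)cc1` has not been measured. It differs from compound 1 by methyl in place of hydrogen on an aromatic carbon. The same change, methyl in place of hydrogen on an aromatic carbon, occurs twice among these compounds: between compound 3 and compound 2, where it gave a 7.8-fold lower number from compound 3 to compound 2 (0.89 log units; beyond the scatter), and between compound 1 and compound 4. The place of the change reads alike in both pairs. The two cores differ by hydroxy in place of hydrogen on an aromatic carbon.

Compound 4 is expected to show a step of a 3.4-fold lower number from compound 1 to compound 4 (0.54 log units; beyond the scatter), a lower number, because the step of a 7.8-fold lower number from compound 3 to compound 2 (0.89 log units; beyond the scatter) went that way. Compound 4 is therefore estimated at 900 nM, expected between 250 nM and 3500 nM.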

Compound 4, solubility: 9600 nM
Compound 4: the middle estimate sits 11-fold (1.03 log units) below what was measured; measured number above the stated range.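

In this assay, the new step is a 3.1-fold higher number from compound 1 to compound 4 (0.49 log units; beyond the scatter) and runs opposite to a 7.8-fold lower number from compound 3 to compound 2 (0.89 log units; beyond the scatter), so methyl in place of hydrogen on an aromatic carbon did not carry its direction from one core to the other in these two pairs. Within the data shown here, with only two pairs, this shows that the direction of the step cannot be assumed to transfer, but it does not establish a rule that the change reverses on hydroxy-bearing cores or a size that applies to other cores. Nothing in the available data bears on why the two steps differ in direction.

The compounds shown leave open how methyl in place of hydrogen reads on the core of compound 3 at the place it occupies in compound 4. They also leave open whether ethyl, methoxy or an amine at that place would follow the step seen with methyl.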